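The source may hold more compounds than are shown below. What is called first, only, known or untested is meant among the compounds shown, and "the series" means these compounds.

Compound 1 `C=CC(=O)Nc1ccc(-c2nc(Cl)cc(Nc3ccc(C(=O)Nc4ccc(F)cc4)cc3)n2)cc1` carries "not determined" (no result reported) in a functional assay on HL-60 cells (Homo sapiens) for antiproliferative activity, read by MTT assay, with a stated time of 48 h (a lower number here means a stronger inhibitor, a higher number a weaker inhibitor), so it stands nowhere on the numbers shown; the only figure in the series comes from compound 2 `C=CC(=O)Nc1ccc(-c2nc(Cl)cc(Nc3ccc(C(=O)Nc4cc(C(F)(F)F)cc(C(F)(F)F)c4)cc3)n2)cc1`, which gives 4790 nM in this assay, a weak inhibitor. Compound 3 `C=CC(=O)Nc1ccc(-c2nc(Cl)cc(Nc3ccc(C(=O)N(C)C)cc3)n2)cc1` differs from compound 1 by dimethylamino in place of (4-fluorophenyl)amino on a carbonyl carbon. Going by the values given here, no measured step covers this change, and no pattern can be drawn from a single value. Relative to compound 2 at 4790 nM, a step of modest size in either direction, or none beyond the scatter, is expected. Compound 3 is estimated at 6000 nM in this assay, within 1500 nM to 25000 nM.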

Compound 3, half-maximal inhibitory concentration: > 50000 nM
Compound 3 ended at the assay's limit; the forecaster's own chance of this, stated with the estimate: 20%; middle value at least 8.3-fold (0.92 log units) away from the limit.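

No step can be read between compound 1 and compound 3, since compound 1 carries no number. Compound 3 gives > 50000 nM, which is a limit of the assay. Going by these compounds, whether (4-fluorophenyl)amino or dimethylamino on the carbonyl carbon gives the stronger inhibitor stays open.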